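The source may hold more compounds than are shown below. What is called first, only, known or untested is meant among the compounds shown, and "the series" means these compounds.

Series on a shared core, varied only in the group on a carbonyl carbon. In an assay on HEK293 cells for displacement of a labelled ligand from NPC1-like intracellular cholesterol transporter 1 (Homo sapiens) (a higher number here means a weaker inhibitor, a lower number a stronger inhibitor), compound 1 `CC(C)(C)c1ccc(C(=O)N2CCC3(CC2)C(=O)N(CC(=O)NCCO)CN3c2ccccc2)cc1` gives 1000 nM. Compound 2 `CC(C)(C)c1ccc(C(=O)N2CCC3(CC2)C(=O)N(CC(=O)N2CCN(S(C)(=O)=O)CC2)CN3c2ccccc2)cc1` gives 19000 nM in this assay, and compound 3 `CC(C)(C)c1ccc(C(=O)N2CCC3(CC2)C(=O)N(CC(=O)N2CCC(O)CC2)CN3c2ccccc2)cc1` gives 4700 nM. Compound 3 thus stands second highest of the three numbers: a 4.7-fold higher number from compound 1 to compound 3 (0.67 log units; beyond the scatter), while a 4.0-fold lower number from compound 2 to compound 3 (0.61 log units; beyond the scatter). Compound 4 `CCOC(=O)C1CCCN(C(=O)CN2CN(c3ccccc3)C3(CCN(C(=O)c4ccc(C(C)(C)C)cc4)CC3)C2=O)C1` is not yet measured; it differs from compound 3 in that (3-(ethoxycarbonyl)piperidin-1-yl in place of 4-hydroxypiperidin-1-yl on a carbonyl carbon). Within the data shown here, no measured step involves 3-(ethoxycarbonyl)piperidin-1-yl. Among the measured compounds shown here, the steps that bear on it are the two that exchange the group on a carbonyl carbon: a 19-fold higher number from compound 1 to compound 2 (1.28 log units; beyond the scatter) and a 4.7-fold higher number from compound 1 to compound 3 (0.67 log units; beyond the scatter); both moves away from (2-hydroxyethyl)amino raise the number, the 4-(methylsulfonyl)piperazin-1-yl case the more so. For compound 4 a modest rise beyond the scatter is therefore expected, a 2.6-fold higher number from compound 3 to compound 4 (0.41 log units; beyond the scatter). For compound 4 in this assay the estimate is 12000 nM, with a range from 4000 nM to 40000 nM.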

Compound 4, half-maximal inhibitory concentration: 8200 nM
Beside the measured number, compound 4's estimate is 1.5-fold (0.17 log units) above it; the measured number falls inside the stated range.
By their numbers in this assay, from the lowest: compound 1; then compounds 3 and 4 (each within the scatter of the next); then compound 2.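

In this assay, exchanging 4-hydroxypiperidin-1-yl for the larger 3-(ethoxycarbonyl)piperidin-1-yl, which has no hydrogen-bond donor, gives a 1.7-fold higher number from compound 3 to compound 4 (0.24 log units; within the scatter), so the hydroxyl donor of compound 3 is not needed to hold its level at this position on a carbonyl carbon. The new group does not close the gap to (2-hydroxyethyl)amino, with an 8.2-fold higher number from compound 1 to compound 4 (0.91 log units; beyond the scatter), yet it stands clear of 4-(methylsulfonyl)piperazin-1-yl, with a 2.3-fold lower number from compound 2 to compound 4 (0.36 log units; beyond the scatter), so compound 4 leaves compound 1 alone at the low end and compound 2 alone at the high end. Nothing available explains these differences.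

Open, on these data alone, is whether the lower number of compound 1 depends on its amide hydrogen or its hydroxyl. A (2-methoxyethyl)amino group would separate the two, and a carboxylic acid in place of the ethyl ester would test the ester itself.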